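Aryl amide series: bromo for ethyl in compound 4

A few compounds are considered here, and "the series" means these few. Any claim that something is new, unique, unknown or untested is made for them only; others in the source may bear on it.

Measured so far:
compound 1 `Cc1cc(NCCN(C)C)nc2ccc(NC(=O)c3ccc(Cl)c(Cl)c3)cc12` — 6670 nM
compound 2 `CCc1ccccc1C(=O)Nc1ccc2nc(N3CCN(CC)CC3)cc(C)c2c1` — 23900 nM
compound 3 `Cc1cc(N2CCCC2)nc2ccc(NC(=O)c3ccc(Cl)c(Cl)c3)cc12` — 43400 nM

In a functional assay on SK-BR-3 cells (Homo sapiens) for antiproliferative activity, read by MTT assay, with a stated time of 72 h (a higher number here means a weaker inhibitor, a lower number a stronger inhibitor), compound 1 gives 6670 nM, compound 2 gives 23900 nM and compound 3 gives 43400 nM. Compound 2 thus stands second highest of the three numbers: compound 3 lies within the scatter of it, while compound 1 lies lower by a gap beyond the scatter. For the measured compounds named here, the only measured step, a 6.5-fold higher number from compound 1 to compound 3 (0.81 log units; beyond the scatter), concerns the amine end of the shared core, a part that compound 2 and compound 4 carry unchanged, so it does not bear on the change considered here.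

Compound 4 `CCN1CCN(c2cc(C)c3cc(NC(=O)c4ccccc4Br)ccc3n2)CC1` differs from compound 2 by bromo in place of ethyl on an aromatic carbon. Going by the values given here, no measured pair alters the (2-ethylphenyl)carbonyl side of the series, so there is no step to calibrate this change against; the two groups exchanged are small and of similar bulk. The step of a 1.2-fold lower number from compound 2 to compound 4 (0.08 log units; within the scatter) is therefore expected to stay within the scatter. For compound 4 the expected value is 20000 nM, with a range from 6000 nM to 60000 nM.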

Compound 4, half-maximal inhibitory concentration: 39200 nM
Beside the measured number, compound 4's estimate is 2.0-fold (0.29 log units) below it; low and high end bracket the measured number.
By their numbers in this assay, from the lowest: compound 1; then compounds 2, 4 and 3 (each within the scatter of the next).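

In this assay, for the compounds shown here, bromo in place of ethyl on an aromatic carbon ortho to a large group gives a 1.6-fold higher number from compound 2 to compound 4 (0.21 log units; within the scatter), the first measured change on this side of the series. At this position, the two groups are not told apart by this read-out, although the exchange swaps a two-carbon group for a single bromine atom. No measured property bears on this result.

Still open, as far as these compounds go, is whether a group of another kind on this aromatic carbon, such as an amine, a methoxy or a carboxylic acid, would produce a step beyond the scatter. Going by these compounds alone, also open is whether bromo and ethyl would still read alike with the (2-(dimethylamino)ethyl)amino group of compound 1 on the shared core, the amine end that gave the only larger step so far, a 6.5-fold higher number from compound 1 to compound 3 (0.81 log units; beyond the scatter).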